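Phenyl to 4-methoxyphenyl: working notes on compound 3

The source may report more compounds than this note shows. Statements on the series, on what has been measured and on what is new or still open speak of the compounds shown alone.

Of the compounds shown here, two have been measured so far in a functional assay on MDA-MB-231 cells (Homo sapiens), read by microscopy and transwell migration, with a stated time of 24 h; a lower number here means a stronger inhibitor, a higher number a weaker inhibitor. Compound 1 `COc1ccc(C(=O)Nc2nc(-c3cc(OC)c(OC)c(OC)c3)cs2)cc1` reads > 25000 nM, which is a limit of the assay and not a number. Among the compounds with values here, compound 2 `COc1cc(-c2csc(N(C)C(=O)c3ccccc3)n2)cc(OC)c1OC` gives 10000 nM, the only true number so far, so it has no measured numerical neighbour to be ranked against.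

Compound 3 `COc1ccc(C(=O)N(C)c2nc(-c3cc(OC)c(OC)c(OC)c3)cs2)cc1` differs from compound 2 by methoxy in place of hydrogen on an aromatic carbon. This places methoxy in place of hydrogen on an aromatic carbon, para to a large group, turning phenyl into 4-methoxyphenyl.

Within the data shown here, no measured pair isolates this change, so no shift beyond the usual scatter is expected in this assay, with considerable uncertainty in either direction. The expected change is a 1.3-fold lower number from compound 2 to compound 3 (0.10 log units; within the scatter). For compound 3 the estimated value is 8000 nM, with an expected range of 2000 nM to 25000 nM.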

Compound 3, half-maximal inhibitory concentration: 312 nM
Compound 3: the middle estimate sits 26-fold (1.41 log units) above what was measured; the whole stated range lies above it.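

In this assay, methoxy in place of hydrogen on an aromatic carbon, para to a large group, gives a 32-fold lower number from compound 2 to compound 3 (1.51 log units; beyond the scatter), so this position responds strongly to substitution, which compound 2 alone could not show. Methyl in place of hydrogen on the amide-type nitrogen matters as well, and of the compounds shown only compound 3 carries both groups. With the 4-methoxyphenyl kept, the methyl gives an at least 80-fold lower number from compound 1 to compound 3 (1.90 log units; beyond the scatter), a step that is read against a limit and not against a number: the limit of > 25000 nM in this assay, at which 1 of the 3 values shown sits.

Still open, from the compounds shown here alone, is whether an amine, a chlorine or a hydroxyl at this position would serve as methoxy does, and whether ethoxy or a longer chain would hold the number. Going by these compounds, a longer chain in place of the methyl on the amide-type nitrogen is equally open.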